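The source may hold more compounds than are shown below. What is called first, only, known or untested is meant among the compounds shown, and "the series" means these compounds.

Compound 1 `CCCC1CCN(CCCCC(=O)c2cc(Cl)c(N)cc2OCc2cc(OC)cc(OC)c2)CC1` gives 7.7 in a functional assay for antagonist activity at 5-hydroxytryptamine receptor 4 (Rattus norvegicus); on this read-out higher numbers stand for higher potency (the scale is a negative logarithm) and lower numbers for lower potency. Compound 2 `COc1cc(COc2cc(N)c(Cl)cc2C(=O)CCCCN2CCC(NC(N)=O)CC2)cc(OC)c1` gives 8.5 in this assay, the higher of the two numbers, with a number 0.80 log units higher from compound 1 to compound 2 (beyond the scatter). Compound 3 `COc1cc(COc2cc(N)c(Cl)cc2C(=O)CCCCN2CCC(CNS(C)(=O)=O)CC2)cc(OC)c1` differs from compound 2 by (methanesulfonamido)methyl in place of ureido on a saturated ring carbon. Among the compounds with values here, only one measured step touches this ring carbon, a number 0.80 log units higher from compound 1 to compound 2 (beyond the scatter), and it was modest; no step compares two different groups there. The change is therefore expected to give a number 0.30 log units lower from compound 2 to compound 3 (within the scatter) in this assay, a number within the scatter. Compound 3 is estimated at 8.2 in this assay, with a range from 7.5 to 8.9.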

Compound 3, negative logarithm of the antagonist equilibrium constant: 8.9
Estimate against measurement, compound 3: 0.70 log units below, within the range that was stated.
By their numbers in this assay, from the lowest: compound 1; then compound 2; then compound 3.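

In this assay, this ring carbon now has its first comparison between two groups other than an alkyl chain, and (methanesulfonamido)methyl in place of ureido gives a number 0.40 log units higher from compound 2 to compound 3 (beyond the scatter). Measured against the propyl-bearing compound, the same group gives a number 1.20 log units higher from compound 1 to compound 3 (beyond the scatter), so the larger group, with its two double bonds outside aromatic rings, is accepted at this carbon. Nothing available bears on the cause of these differences. Open, from the compounds shown here alone, is how a primary amine, a carboxylic acid or a longer chain carrying the methanesulfonamido group would compare at this ring carbon.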